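Halogen swaps on a benzothiazole leave MDCK cytotoxicity unchanged

The source may hold more compounds than are shown below. What is called first, only, known or untested is meant among the compounds shown, and "the series" means these compounds.

Three compounds share a core made of a flavone joined through a four-carbon chain to an aminobenzothiazole. Compound 1 `O=c1cc(-c2ccccc2)oc2cc(OCCCCNc3nc4ccccc4s3)cc(O)c12` carries no halogen on the benzothiazole ring; in an ADME assay on MDCK cells (Canis lupus familiaris) for cytotoxicity, read by sulforhodamine B assay, with a stated time of 48 h (on this read-out higher numbers stand for weaker inhibition and lower numbers for stronger inhibition), compound 1 gives 348 ug/mL. Compound 2 `O=c1cc(-c2ccccc2)oc2cc(OCCCCNc3nc4ccc(Cl)cc4s3)cc(O)c12` carries a chloro group and gives 338 ug/mL in this assay. Compound 3 `O=c1cc(-c2ccccc2)oc2cc(OCCCCNc3nc4ccc(Br)cc4s3)cc(O)c12` carries a bromo group and gives 289 ug/mL in this assay, the lowest of the three numbers, yet its steps to compound 2 and to compound 1 both lie within the scatter.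

Compound 4 `O=c1cc(-c2ccccc2)oc2cc(OCCCCNc3nc4ccc(F)cc4s3)cc(O)c12` is the next member. Its difference from compound 3 is fluoro in place of bromo on an aromatic carbon.

The steps seen so far all bear on this change: a 1.0-fold lower number from compound 1 to compound 2 (0.01 log units; within the scatter), a 1.2-fold lower number from compound 1 to compound 3 (0.08 log units; within the scatter) and a 1.2-fold lower number from compound 2 to compound 3 (0.07 log units; within the scatter). Each of them stays within the scatter, so replacing one halogen with another, or adding one, has not shifted the read-out so far.

Compound 4 is therefore expected to sit close to compound 3, with a step of a 1.1-fold higher number from compound 3 to compound 4 (0.04 log units; within the scatter) that stays within the scatter. The estimate for compound 4 in this assay is 320 ug/mL, in a range from 220 ug/mL to 480 ug/mL.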

Compound 4, half-maximal inhibitory concentration: 324 ug/mL
The estimate for compound 4 lay 1.0-fold (0.01 log units) below the measured number; the range from low to high includes it.
By their numbers in this assay, from the lowest: compounds 3, 4, 2 and 1 (each within the scatter of the next).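

Compound 4 completes a set of hydrogen, fluoro, chloro and bromo at the same place on the six-membered aromatic ring of carbon only, and in this assay the fluoro group separates itself from none of the others. Its step from bromo (a 1.1-fold higher number from compound 3 to compound 4 (0.05 log units; within the scatter)), its step from chloro (a 1.0-fold lower number from compound 2 to compound 4 (0.02 log units; within the scatter)) and its step from hydrogen (a 1.1-fold lower number from compound 1 to compound 4 (0.03 log units; within the scatter)) all stay within the scatter, so the earlier finding for chloro and bromo now holds for a third halogen and for every pairing among these four compounds. No measurement offered here explains why the read-out stays the same across these swaps.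

As far as these compounds go, all four groups at this place are either hydrogen or a single halogen atom, so it remains open whether a different kind of group there, such as an amine, a methoxy group or a carboxylic acid, would move the number beyond the scatter. The compounds shown also keep the same four-carbon chain and the same flavone, which leaves open what a longer chain would do to this read-out.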